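Ring contraction of the cyclic amine on the shared core

The compounds below may be only part of what the source reports. "The series", "measured", "known", "first", "only" and "open" are said of these compounds alone.

Measured so far:
compound 1 `O=S(=O)(c1ccccc1)c1cnc2ccccc2c1N1CCCCCC1` — 310 nM
compound 2 `CCN(CC)c1c(S(=O)(=O)c2ccc(C)cc2)cnc2ccccc12` — 201 nM

In an assay on isolated protein for displacement of a labelled ligand from metabotropic glutamate receptor 5 (Homo sapiens), with a stated time of 60 min (on this read-out higher numbers stand for weaker inhibition and lower numbers for stronger inhibition), compound 1 gives 310 nM and compound 2 gives 201 nM. The two numbers lie within the scatter of each other, so compound 1 cannot be placed above or below compound 2 on this read-out; it stands at one end of a pair that does not separate. Compound 1 and compound 2 differ in more than one place, so no single step can be read from them, only that both sit in the same range.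

Compound 3 `O=S(=O)(c1ccccc1)c1cnc2ccccc2c1N1CCCCC1` is the next member. It differs from compound 1 in one place: piperidin-1-yl in place of azepan-1-yl on an aromatic carbon. Among the compounds with values here, no measured pair isolates this kind of change, so nothing fixes its size. The expectation for this assay is a step of no more than the scatter, with no direction that the data support, expressed as a 1.2-fold lower number from compound 1 to compound 3 (0.08 log units; within the scatter). For compound 3 the estimated value in this assay is 260 nM, with a range from 110 nM to 650 nM.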

Compound 3, inhibition constant: 307 nM
Estimate against measurement, compound 3: 1.2-fold (0.07 log units) below; low and high end bracket the measured number.
By their numbers in this assay, from the lowest: compounds 2, 3 and 1 (each within the scatter of the next).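

In this assay, within the data shown here, the change to piperidin-1-yl in place of azepan-1-yl on an aromatic carbon gives a 1.0-fold lower number from compound 1 to compound 3 (0.00 log units; within the scatter) and is the first step that isolates a single place. At this place, opposite the ring nitrogen, the read-out does not separate the six-membered ring from the seven-membered ring, so the size of the cyclic amine between these two members leaves the number unmoved on the shared core. No available evidence bears on why the two rings read alike.

Whether the same holds further along is open: pyrrolidin-1-yl, with a smaller ring, or morpholin-4-yl, with oxygen as a second hetero atom in the ring, on the same aromatic carbon could still stay in this range or could leave it. Among these compounds, compound 2 differs from both compound 1 and compound 3 in more than one place, so no step to it can be read, and a comparison of an open-chain amine with a cyclic amine at this place remains unresolved.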